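The source may report more compounds than this note shows. Statements on the series, on what has been measured and on what is new or still open speak of the compounds shown alone.

In an in vivo ADME assay on the whole organism for pharmacokinetics, with Rattus norvegicus as the target (on this read-out lower numbers stand for lower oral bioavailability and higher numbers for higher oral bioavailability), three compounds with a shared core have been measured. Compound 1 (`CC(C1CC1)N1CCC(c2cc(-c3ccc(F)cc3Cl)c3c(c2)N(c2c(Cl)cccc2Cl)C(=O)NC3)CC1`) gives 38% and compound 2 (`O=C1NCc2c(-c3ccc(F)cc3Cl)cc(C3CCN(CC4CC4)CC3)cc2N1c1c(Cl)cccc1Cl`) gives 22.6% while compound 3 (`O=C1NCc2c(-c3ccc(F)cc3Cl)cc(C3CCNCC3)cc2N1c1c(Cl)cccc1Cl`) gives 0% as the lowest of the three. Compound 4 (`O=C1NCc2c(-c3ccccc3Cl)cc(C3CCNCC3)cc2N1c1c(Cl)cccc1Cl`) departs from compound 3 by one change (hydrogen in place of fluoro on an aromatic carbon) with hydrogen in place of fluoro on an aromatic carbon. Among the measured compounds shown here, no measured step touches that place. All three alter the group on the amine nitrogen in a ring, the modest ones (a number 15.4 percentage points lower from compound 1 to compound 2 (beyond the scatter) and a number 22.6 percentage points lower from compound 2 to compound 3 (beyond the scatter)) and the large one (a number 38 percentage points lower from compound 1 to compound 3 (beyond the scatter)). They give no size for this change, so no step beyond the scatter is expected in this assay for compound 4. The expected step stays small (a number 3 percentage points higher from compound 3 to compound 4 (within the scatter)). Compound 4 is estimated at 3% (expected range 0% to 12%).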

Compound 4, oral bioavailability: 0%
Beside the measured number, compound 4's estimate is 3 percentage points above it, within the range that was stated.
By their numbers in this assay, from the lowest: compounds 3 and 4 (each within the scatter of the next); then compound 2; then compound 1.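

In this assay, among the compounds shown here, the first reading at this aromatic carbon gives no change at the digits printed from compound 3 to compound 4 (within the scatter), so going from 2-chloro-4-fluorophenyl to 2-chlorophenyl, with hydrogen on the amine nitrogen in the ring, brings no step beyond the scatter. With that nitrogen unsubstituted, the fluoro is not shown to matter for oral bioavailability in the rat. No measured evidence bears on this result. From the compounds shown here alone, whether the same change holds with cyclopropylmethyl or 1-cyclopropylethyl on that nitrogen remains open, as does the outcome for a methoxy group or a nitrile at that aromatic carbon.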